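Benzamide series: bromo to trifluoromethyl on two cores

This account rests on a few compounds, and the source may have more. Where it says the series, first, only, none or still open, it means among the compounds named here.

Compound 1 `COc1cc(Cl)ccc1C(=O)Nc1cc(Br)ccc1O` and compound 3 `COc1ccc(Cl)cc1C(=O)Nc1ccc(Br)cc1O` are built from the same atoms joined differently; the difference between the two cores is not broken down here. In a functional assay on HepG2 cells (Homo sapiens) for cytotoxicity, with a stated time of 24 h (a higher number here means a weaker inhibitor, a lower number a stronger inhibitor), compound 1 gives 5630 nM and compound 3 gives 7980 nM, two values within the scatter of each other. Compound 2 `COc1cc(Cl)ccc1C(=O)Nc1cc(C(F)(F)F)ccc1O` differs from compound 1 by trifluoromethyl in place of bromo on an aromatic carbon, and the step is a 4.5-fold higher number from compound 1 to compound 2 (0.65 log units; beyond the scatter). In this assay compound 2 gives 25400 nM. Compound 4 `COc1ccc(Cl)cc1C(=O)Nc1ccc(C(F)(F)F)cc1O` carries the same kind of change relative to compound 3, namely (trifluoromethyl in place of bromo on an aromatic carbon); the surroundings of the place differ, since in compound 2 the site is meta to a large group and para to a hydroxy group, whereas in compound 4 it is meta to a hydroxy group and para to a large group. Going by the values given here, only one instance of this change has been measured, so any expectation rests on it alone. Among the compounds with values here, compound 4 is expected to show a step of a 3.8-fold higher number from compound 3 to compound 4 (0.58 log units; beyond the scatter) in this assay, because the measured step of a 4.5-fold higher number from compound 1 to compound 2 (0.65 log units; beyond the scatter) is the only guide. The estimate for compound 4 is 30000 nM, with a range from 12000 nM to 90000 nM.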

Compound 4, half-maximal inhibitory concentration: 4910 nM
Estimate against measurement, compound 4: 6.1-fold (0.79 log units) above; measured number below the stated range.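

In this assay, trifluoromethyl in place of bromo does not carry over from one core to the other, and the new step, a 1.6-fold lower number from compound 3 to compound 4 (0.21 log units; within the scatter), sets the two cores apart: the same change on two cores in this assay, a 4.5-fold higher number (0.65 log units; beyond the scatter) from compound 1 to compound 2 and a 1.6-fold lower number (0.21 log units; within the scatter) from compound 3 to compound 4, 7.3-fold (0.87 log units) apart, beyond the scatter of two such steps. Going by these compounds alone, for these two pairs, the outcome of the change depends on the core, so the step on the core of compound 1 is no guide to the step on the core of compound 3. The pairs do not show which feature of the two cores accounts for the gap, and they set no rule for the wider series.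

Open, on these data alone, is how a nitrile, an amine or a carboxylic acid in the same place would behave on each core. Also open, as far as these compounds go, is whether the two cores would part again with those groups.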